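A few compounds are considered here, and "the series" means these few. Any claim that something is new, unique, unknown or untested is made for them only; others in the source may bear on it.

Compound 1 `COc1cccc(N2C(=O)COc3ccc(-c4cnc(Cl)c(NS(=O)(=O)c5ccc(F)cc5)c4)cc32)c1`: in a functional assay on HCT-116 cells (Homo sapiens) for antiproliferative activity, read by MTT assay, with a stated time of 72 h (a higher number here means a weaker inhibitor, a lower number a stronger inhibitor), compound 1 gives > 40000 nM, which is a limit of the assay and not a number.
Compound 2 `COc1cccc(N2C(=O)COc3ccc(-c4cnc(OC)c(NS(=O)(=O)c5ccc(F)cc5)c4)cc32)c1`: compound 2 gives > 40000 nM, again only a limit.
Compound 3 `O=C1COc2ccc(-c3cnc4ccccc4c3)cc2N1`: compound 3 gives > 40000 nM, also a limit.

Every value here sits at the same limit (the limit of > 40000 nM in this assay, at which 3 of the 3 values shown sit), so compound 1 stands nowhere on a scale, only at that limit. Going by the values given here, the single one-place step, a step that the two limits leave unreadable from compound 1 to compound 2, cannot be read, since both of its ends are limits.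

Compound 4 `O=C1COc2ccc(-c3cnc(Cl)c(NS(=O)(=O)c4ccc(F)cc4)c3)cc2N1C1CC1` differs from compound 1 by cyclopropyl in place of 3-methoxyphenyl on an amide-type nitrogen in a ring. Among the compounds with values here, no measured step touches this change, so no direction or size can be drawn from the three values. Compound 4 is therefore expected to stay near the limit, at about 40000 nM with a range of 8000 nM to 100000 nM. The step from compound 1 to compound 4 is expected to be a number no higher from compound 1 to compound 4 (the limit leaves the size open), not beyond the scatter.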

Compound 4, half-maximal inhibitory concentration: 12400 nM
The estimate for compound 4 lay 3.2-fold (0.51 log units) above the measured number, within the range that was stated.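

Cyclopropyl in place of 3-methoxyphenyl on the amide-type nitrogen in a ring gives an at least 3.2-fold lower number from compound 1 to compound 4 (0.50 log units; beyond the scatter), the first step here that can be read. Going by these compounds, this nitrogen substituent is therefore a place where a change registers, while the size of the step stays open on one side. Compound 4 alone gives a number rather than a limit in this assay: the limit of > 40000 nM in this assay, at which 3 of the 4 values shown sit.

On these data alone, it remains open whether a methyl, a longer chain such as n-butyl, or a chain ending in an amine on this nitrogen would lower the number further. As far as these compounds go, it is also open whether methoxy in place of chloro reads differently with cyclopropyl present.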